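Compound 4: removing the bromo group from compound 3

A few compounds are considered here, and "the series" means these few. Any claim that something is new, unique, unknown or untested is made for them only; others in the source may bear on it.

In a functional assay on PC-3 cells (Homo sapiens) for inhibition, read by sulforhodamine B assay, with a stated time of 48 h (on this read-out higher numbers stand for weaker inhibition of growth and lower numbers for stronger inhibition of growth), compound 1 (`CCOC(=O)c1nn(-c2ccccc2)c(-c2ccccc2)c1CNC(C)(C)C`) gives 39900 nM; 91700 nM (2 entries) across its two entries. Compound 2 (`CC(C)(C)NCc1c(C(=O)O)nn(-c2ccccc2)c1-c1ccc(Cl)cc1`), which carries chloro, gives 145000 nM as a single entry.

Compound 3 (`CC(C)(C)NCc1c(C(=O)O)nn(-c2ccccc2)c1-c1ccc(Br)cc1`) stands at > 585000 nM and this is a limit of the assay, not a number.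

Among the measured compounds shown here, the exchange of chloro for bromo gives an at least 4.0-fold higher number from compound 2 to compound 3 (0.60 log units; beyond the scatter) and is the only measured step that bears on the next change. Compound 4 (`CC(C)(C)NCc1c(C(=O)O)nn(-c2ccccc2)c1-c1ccccc1`) has hydrogen in place of bromo on an aromatic carbon, para to a large group (hydrogen in place of bromo on an aromatic carbon). The measured step swaps one halogen for another and removes none, so it is only a loose guide.

Taking compound 2 at 145000 nM as that guide, a move towards stronger inhibition of growth is expected for the 4-bromophenyl to phenyl change. The expected size is an at least 2.5-fold lower number from compound 3 to compound 4 (0.40 log units; beyond the scatter) as an estimate set against a limit. The estimated value for compound 4 is 230000 nM (expected range 90000 nM to 600000 nM).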

Compound 4, concentration for 50% growth inhibition: > 716000 nM
Compound 4: only a limit was reported (the forecaster's own chance of this, stated with the estimate: 25%); middle value at least 3.1-fold (0.49 log units) away from the limit.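

In this assay, hydrogen in place of the halogen gives no readable growth inhibition: compound 4, like compound 3, is reported only as a limit of the assay. Against chloro the change reads as an at least 4.9-fold higher number from compound 2 to compound 4 (0.69 log units; beyond the scatter), so compound 2 now stands apart from two neighbours at this position rather than one, and among these three carboxylic acids only the chloro compound carries a number. The step between the bromo and hydrogen compounds cannot be read, as both of its ends are limits.

Left open is how fluoro or methoxy in the same place would read in this assay, and how hydrogen and bromo rank against each other. Also open, from the compounds shown here alone, is whether the 4-chlorophenyl group would keep its difference from phenyl alongside the ethyl ester of compound 1.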